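The compounds below may be only part of what the source reports. "The series", "measured", "known", "first", "only" and "open" are said of these compounds alone.

Compounds measured in an assay for binding affinity to metabotropic glutamate receptor 5 (Rattus norvegicus); a higher number here means a weaker inhibitor, a lower number a stronger inhibitor:
- compound 1, `Cc1ccncc1-c1cc(F)cc(-n2nnc(-c3ncc[nH]3)n2)c1`: 3.5 nM
- compound 2, `N#Cc1cccc(-n2nnc(-c3ncc[nH]3)n2)c1`: 34 nM
- compound 3, `N#Cc1cccc(-n2nnc(-c3ccccn3)n2)c1`: 102 nM

Compound 3 gives the highest number of the three in this assay. Its nearest neighbour is compound 2, which differs from it only in the five-membered ring attached to the shared core; the step of a 3.0-fold higher number from compound 2 to compound 3 (0.48 log units; beyond the scatter) is modest but beyond the scatter. Compound 1 stands much further away, with a value far lower than that of compound 3.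

The compound that has not yet been measured is compound 4, `N#Cc1cccc(-n2nnc(-c3cc[nH]n3)n2)c1`. It is derived from compound 3 by the change (1H-pyrazol-3-yl in place of pyridin-2-yl on an aromatic carbon). Among the measured steps only one bears on this change: the step from compound 2 to compound 3, in which a five-membered ring with a ring nitrogen bearing a hydrogen was exchanged for pyridin-2-yl and the number rose. Compound 4 reverses that kind of exchange, bringing back a five-membered ring with a hydrogen-bond donor, though not the same ring as in compound 2. The expected direction is therefore toward a lower number, of about the size seen in the step from compound 2 to compound 3, and the estimated step is a 2.6-fold lower number from compound 3 to compound 4 (0.41 log units; beyond the scatter). For compound 4 in this assay the estimate is 40 nM, within a range from 15 nM to 120 nM.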

Compound 4, inhibition constant: > 2000 nM
Compound 4 gave a limit, no number (the forecaster's own chance of this, stated with the estimate: 2%); middle value at least 50-fold (1.69 log units) from the limit.
By their numbers in this assay, from the lowest: compound 1; then compound 2; then compound 3. At a limit, above all of these: compound 4.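

In this assay compound 4 stands at a limit of the assay and has no number: the limit of > 2000 nM in this assay, at which 1 of the 4 values shown sits. The new change is far from neutral at this position: the record gives an at least 19-fold higher number from compound 3 to compound 4 (1.29 log units; beyond the scatter), so on this aromatic carbon, between two ring nitrogen atoms, 1H-pyrazol-3-yl fares much worse than pyridin-2-yl, which the earlier compounds could not have shown. The comparison with 1H-imidazol-2-yl is wider still, at an at least 58-fold higher number from compound 2 to compound 4 (1.76 log units; beyond the scatter), so two five-membered aromatic rings that each carry a hydrogen on a ring nitrogen are far apart here, and the advantage seen for compound 2 over compound 3 belongs to 1H-imidazol-2-yl alone and does not extend to every such ring.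

Going by these compounds, how far beyond the limit compound 4 really lies remains unknown, so the true size of both steps stays open. The compounds shown also cannot separate the effect of the hydrogen on the ring nitrogen from that of the arrangement of the ring atoms, and a methyl group on that pyrazole nitrogen or a plain phenyl ring at this place would be needed to address that question.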